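Exchanging the aryl group on the carbamoyl compound

A few compounds are considered here, and "the series" means these few. Any claim that something is new, unique, unknown or untested is made for them only; others in the source may bear on it.

compound 1 `COc1ccc(-c2cc3c(cn2)[nH]c(=O)n3-c2cc(OC)c(OC)c(OC)c2)cc1F`: 2210 nM
compound 2 `CCOc1ccc(-c2cc3c(cn2)[nH]c(=O)n3-c2cc(OC)c(OC)c(OC)c2)cc1`: 3730 nM
compound 3 `COc1ccc(-c2cc3c([nH]c(=O)n3-c3cc(OC)c(OC)c(OC)c3)c(C(N)=O)n2)cc1F`: 330 nM

All three values come from a functional assay on HeLa cells (Homo sapiens) for antiproliferative activity, read by MTT assay, with a stated time of 48 h; a lower number here means a stronger inhibitor, a higher number a weaker inhibitor. Compound 3 has the lowest number of the set, and the carbamoyl group separates it from its nearest neighbour: a 6.7-fold lower number from compound 1 to compound 3 (0.83 log units; beyond the scatter). Compound 4 `CCOc1ccc(-c2cc3c([nH]c(=O)n3-c3cc(OC)c(OC)c(OC)c3)c(C(N)=O)n2)cc1` has not yet been measured. It differs from compound 3 in one place: 4-ethoxyphenyl in place of 3-fluoro-4-methoxyphenyl on an aromatic carbon. The new group, 4-ethoxyphenyl, replaces 3-fluoro-4-methoxyphenyl on an aromatic carbon next to the ring nitrogen and meta to a carbamoyl group.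

The same exchange has been measured once, in the pair without the carbamoyl group: a 1.7-fold higher number from compound 1 to compound 2 (0.23 log units; within the scatter). That single step is the closest guide, and it is small. For the measured compounds named here, no measured pair shows the exchange with the carbamoyl group present, so its carry-over to compound 3 remains an assumption. The expectation is therefore a small rise, probably not clearly beyond the scatter, in this assay. The estimated outcome is a 1.5-fold higher number from compound 3 to compound 4 (0.18 log units; within the scatter). For compound 4 the expected value is 500 nM, with an estimated range of 220 nM to 1100 nM.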

Compound 4, half-maximal inhibitory concentration: 4030 nM
Estimate against measurement, compound 4: 8.1-fold (0.91 log units) below, and the stated range ends below it.
By their numbers in this assay, from the lowest: compound 3; then compounds 1, 2 and 4 (each within the scatter of the next).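

In this assay, the exchange of 3-fluoro-4-methoxyphenyl for 4-ethoxyphenyl depends on whether the carbamoyl group is present, and with it the change gives a 12-fold higher number from compound 3 to compound 4 (1.09 log units; beyond the scatter), a much larger step than the one seen without it: the same change on two cores in this assay, a 1.7-fold higher number (0.23 log units; within the scatter) from compound 1 to compound 2 and a 12-fold higher number (1.09 log units; beyond the scatter) from compound 3 to compound 4, 7.2-fold (0.86 log units) apart, beyond the scatter of two such steps. The carbamoyl step depends in turn on the aryl group, since it gives only a 1.1-fold higher number from compound 2 to compound 4 (0.03 log units; within the scatter) with 4-ethoxyphenyl, against a 6.7-fold lower number from compound 1 to compound 3 (0.83 log units; beyond the scatter) with 3-fluoro-4-methoxyphenyl: the same change on two cores in this assay, a 6.7-fold lower number (0.83 log units; beyond the scatter) from compound 1 to compound 3 and a 1.1-fold higher number (0.03 log units; within the scatter) from compound 2 to compound 4, 7.2-fold (0.86 log units) apart, beyond the scatter of two such steps. Among these four compounds, therefore, the lower number appears only where carbamoyl and 3-fluoro-4-methoxyphenyl occur together, in compound 3, and neither the carbamoyl group nor the aryl exchange has a single effect that can be carried from one core to the other.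

The exchange alters the fluorine and the alkoxy chain at once, so the compounds shown leave open which of the two matters; a plain 4-methoxyphenyl or a 3-fluoro-4-ethoxyphenyl group on the carbamoyl core would separate them. They also leave open whether the dependence on the aryl group is particular to the carbamoyl group or extends to another group at that carbon, such as a nitrile or a carboxylic acid.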